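The source may report more compounds than this note shows. Statements on the series, on what has been measured and on what is new or still open speak of the compounds shown alone.

Measured so far in a functional assay on BV-173 cells (Homo sapiens) for cytotoxicity, read by MTT assay, with a stated time of 72 h; on this read-out lower numbers stand for stronger inhibition and higher numbers for weaker inhibition:

Compound 1 `CN(C)Cn1c(=O)oc2cc(C(=O)/C=C/c3ccccc3)ccc21` — 6600 nM
Compound 2 `COc1ccccc1N1CCN(Cn2c(=O)oc3cc(C(=O)/C=C/c4ccccc4)ccc32)CC1` — 9200 nM
Compound 3 `COc1ccc(/C=C/C(=O)c2ccc3c(c2)oc(=O)n3CN(C)C)cc1` — 17700 nM

Compound 1 and compound 3 share a core and differ by methoxy in place of hydrogen on an aromatic carbon; this gave a 2.7-fold higher number from compound 1 to compound 3 (0.43 log units; beyond the scatter). Compound 2 carries a different core; the difference between the cores of compound 1 and compound 2 is not broken down here, and in this assay the two values of compound 1 and compound 2 lie within the scatter of each other, so no order is read from them.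

Compound 4 `COc1ccc(/C=C/C(=O)c2ccc3c(c2)oc(=O)n3CN2CCN(c3ccccc3OC)CC2)cc1` is not yet measured. It differs from compound 2 by methoxy in place of hydrogen on an aromatic carbon, the same change as that from compound 1 to compound 3, at a place described in the same words. Among the compounds with values here, the only guide is the single measured step: because the change from compound 1 to compound 3 gave a 2.7-fold higher number from compound 1 to compound 3 (0.43 log units; beyond the scatter), a step of similar size is expected from compound 2 to compound 4, namely a 2.5-fold higher number from compound 2 to compound 4 (0.40 log units; beyond the scatter). Compound 4 is thus estimated at 23000 nM in this assay, with a range of 10000 nM to 50000 nM; one example is a thin basis, so the range is kept wide.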

Compound 4, half-maximal inhibitory concentration: 5400 nM
The estimate for compound 4 lay 4.3-fold (0.63 log units) above the measured number; the whole stated range lies above it.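

In this assay the change from phenyl to 4-methoxyphenyl on the core of compound 2 gave a 1.7-fold lower number from compound 2 to compound 4 (0.23 log units; within the scatter), so the rise in the number seen on the core of compound 1 did not carry over. The same change therefore cannot be carried unaltered between these two cores: the same change on two cores in this assay, a 2.7-fold higher number (0.43 log units; beyond the scatter) from compound 1 to compound 3 and a 1.7-fold lower number (0.23 log units; within the scatter) from compound 2 to compound 4, 4.6-fold (0.66 log units) apart, beyond the scatter of two such steps

This shows that, across these four compounds, the outcome of the change depends on the core; it does not show a gain from methoxy on the core of compound 2, as that step stays within the scatter, and with one pair per core it neither identifies the part of the core responsible nor gives a rule for any further core.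

Open, going by these compounds, is whether a fluorine, a hydroxyl group or a carboxylic acid in place of the methoxy would also give different outcomes on the two cores. Also open, on these data alone, is whether a longer chain, such as ethoxy, would follow the methoxy on each core.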